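Hexylsulfanyl for benzyloxy: expected cell tolerance

The source may report more compounds than this note shows. Statements on the series, on what has been measured and on what is new or still open speak of the compounds shown alone.

Measured compounds:
Compound 1 `COCCOc1nc(N)nc2c1ncn2/C=C1/CC1(CO)CO` in an ADME assay on MOLT-3 cells (Homo sapiens) for cytotoxicity, with a stated time of 7 days; a higher number here means that more compound is tolerated, a lower number that less compound is tolerated: > 20000 nM
Compound 2 `Nc1nc(OCc2ccccc2)c2ncn(/C=C3/CC3(CO)CO)c2n1` in this assay: > 20000 nM
Compound 3 `CC(C)CNc1nc(N)nc2c1ncn2/C=C1/CC1(CO)CO` in this assay: "not determined" (no result reported)

In this assay compound 1 gives > 20000 nM, which is a limit of the assay and not a number. Compound 2 gives > 20000 nM, likewise a limit. Within the data shown here, the only step between measured compounds, a step that the two limits leave unreadable from compound 1 to compound 2, therefore cannot be read. Compound 2 thus stands at the limit of > 20000 nM in this assay, at which 2 of the 3 values shown sit, with compound 3 contributing no number at all.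

Compound 4 `CCCCCCSc1nc(N)nc2c1ncn2/C=C1/CC1(CO)CO` differs from compound 2 by hexylsulfanyl in place of benzyloxy on an aromatic carbon. Among the measured compounds shown here, no measured step bears on this change, so no shift beyond the scatter can be expected in either direction. Compound 4 is expected to show a step that the limit leaves unreadable from compound 2 to compound 4, most likely again only a limit, with an estimate of 25000 nM and a range from 8000 nM to 70000 nM.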

Compound 4, half-maximal cytotoxic concentration: > 20000 nM
Compound 4 gave a limit, no number; the forecaster's own chance of this, stated with the estimate: 80%; the middle value does not contradict the limit.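

Compound 4 gives a limit of the assay and not a number, as do compound 1 and compound 2, so no step among these three can be read: the limit of > 20000 nM in this assay, at which 3 of the 4 values shown sit.

The compounds shown leave open whether in this assay hexylsulfanyl, benzyloxy and 2-methoxyethoxy differ at all.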